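The source may report more compounds than this note shows. Statements on the series, on what has been measured and on what is new or still open speak of the compounds shown alone.

Compound 1 `FC(F)(F)c1ccc2[nH]c(-c3ccccc3)nc2c1` is the starting point. In a functional assay for antagonist activity at Neuropeptides B/W receptor type 1 (Homo sapiens), read by cAMP accumulation (on this read-out higher numbers stand for weaker inhibition and lower numbers for stronger inhibition), compound 1 gives 1200 nM, the lowest of the two numbers measured here. The nearest is compound 3 `CC(=O)c1ccc(-c2nc3cc([N+](=O)[O-])ccc3[nH]2)cc1`, which in this assay gives 9320 nM. Compound 2 `NS(=O)(=O)c1ccc(-c2nc3cc([N+](=O)[O-])ccc3[nH]2)cc1` reaches only a limit in this assay, > 31600 nM, as noted in the limit of > 31600 nM in this assay, at which 1 of the 3 values shown sits. For the measured compounds named here, the one measured step, an at least 3.3-fold lower number from compound 2 to compound 3 (0.53 log units; beyond the scatter), swaps groups on a different part of the molecule and so bears only loosely on the change considered now. Compound 4 `Cn1cc(-c2ccc(-c3nc4cc(C(F)(F)F)ccc4[nH]3)cc2)cn1` differs from compound 1 by 1-methyl-1H-pyrazol-4-yl in place of hydrogen on an aromatic carbon. Lacking a measured step of this kind, no change beyond the scatter is expected, so the estimate for compound 4 is 1200 nM, between 300 nM and 5000 nM, a step of no change at the digits printed from compound 1 to compound 4 (within the scatter).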

Compound 4, half-maximal inhibitory concentration: 1470 nM
For compound 4 the middle estimate is 1.2-fold (0.09 log units) below the measured one; the range from low to high includes it.
By their numbers in this assay, from the lowest: compounds 1 and 4 (each within the scatter of the next); then compound 3. At a limit, above all of these: compound 2.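

In this assay the new result is a 1.2-fold higher number from compound 1 to compound 4 (0.09 log units; within the scatter), so on this aromatic carbon, para to a large group, the core of compound 1 accepts a 1-methyl-1H-pyrazol-4-yl group of 6 heavy atoms without a change beyond the scatter. Compound 2 and compound 3 also carry groups at this place, but on a different core, so they could not show this. Nothing measured here explains this outcome.

Going by these compounds, whether an amine, a carboxylic acid or a longer chain at this place would lower the number stays open.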